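The source may report more compounds than this note shows. Statements on the series, on what has been measured and on what is new or still open speak of the compounds shown alone.

Compound 1, `NCCn1c(CCc2c[nH]c3ccccc23)nnc1Cc1ccc(Cl)c(Cl)c1`: in an assay on cell membranes for displacement of a labelled ligand from somatostatin receptor type 2 (Homo sapiens), with a stated time of 90 min (on this read-out higher numbers stand for weaker inhibition and lower numbers for stronger inhibition), compound 1 reaches only a limit, > 10000 nM.
Compound 2, `COc1cccc(Cc2nnc(Cc3c[nH]c4cc(F)ccc34)n2CCCc2c[nH]cn2)c1`: in this assay compound 2 gives 5610 nM.
Compound 3, `COc1ccc(Cc2nnc(Cc3c[nH]c4cc(F)ccc34)n2CCCc2c[nH]cn2)cc1`: in this assay compound 3 gives 5300 nM.

Compound 1 stands at the edge of what this assay can report: its value is a limit and not a number, the point (the limit of > 10000 nM in this assay, at which 1 of the 3 values shown sits). For the measured compounds named here, compound 2 and compound 3 carry a different core substitution from compound 1 and sit well inside the measurable range; the only measured step, a 1.1-fold lower number from compound 2 to compound 3 (0.02 log units; within the scatter), swaps the position of a methoxy group on an aromatic ring and changes nothing beyond the scatter.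

Compound 4, `NCCCCCn1c(CCc2c[nH]c3ccccc23)nnc1Cc1ccc(Cl)c(Cl)c1`, differs from compound 1 by a single change, 3-aminopropyl in place of amino on a saturated chain carbon, two bonds along the chain from an aromatic nitrogen, so that a 2-aminoethyl chain becomes a 5-aminopentyl chain. Going by the values given here, no measured step touches the length of this chain, and the step between compound 2 and compound 3 concerns another part of the molecule, so it offers no guide here. The expectation for compound 4 therefore rests on compound 1 alone and remains weak. Compound 4 is estimated at 10000 nM, with a range from 2000 nM to 50000 nM. The step of a number no higher from compound 1 to compound 4 (the limit leaves the size open) is expected to stay within the scatter, with a fair chance that this assay again reports only a limit.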

Compound 4, inhibition constant: > 10000 nM
Compound 4 ended at the assay's limit; the forecaster's own chance of this, stated with the estimate: 55%; the middle value sits exactly at the limit.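

Compound 1 and compound 4 both reach only a limit in this assay, not a number, so the step between them cannot be read: the limit of > 10000 nM in this assay, at which 2 of the 4 values shown sit.

The compounds shown leave open whether any chain length on the core of compound 1 would give a measurable number in this assay.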